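Chain Lengthening on the Shared Core and Cytotoxicity

A few compounds are considered here, and "the series" means these few. Any claim that something is new, unique, unknown or untested is made for them only; others in the source may bear on it.

Compound 1 `Cc1c(Oc2ccccc2OCCn2ccc(=O)[nH]c2=O)cc(F)c2ccc(C#N)cc12`: > 100000 nM
Compound 2 `CCc1cc(Oc2ccccc2OCCn2ccc(=O)[nH]c2=O)c(C)c2cc(C#N)ccc12`: 12000 nM

In a toxicity assay on MT2 cells (Homo sapiens) for cytotoxicity, read by MTT assay (on this read-out higher numbers stand for lower toxicity in this test and lower numbers for higher toxicity in this test), compound 1 reaches only a limit, > 100000 nM. Compound 2 gives the sole number shown, 12000 nM. The other value shown is a limit (the limit of > 100000 nM in this assay, at which 1 of the 2 values shown sits). Going by the values given here, the one measured step, an at least 8.3-fold lower number from compound 1 to compound 2 (0.92 log units; beyond the scatter), concerns a different change and so says nothing direct about the next one. Compound 3 `CCCc1cc(Oc2ccccc2OCCn2ccc(=O)[nH]c2=O)c(C)c2cc(C#N)ccc12` differs from compound 2 by methyl in place of hydrogen on a saturated chain carbon, two bonds along the chain from an aromatic carbon. Among the compounds with values here, with no measured step bearing on this change, compound 3 is expected to remain within the scatter of compound 2, giving a 1.3-fold lower number from compound 2 to compound 3 (0.12 log units; within the scatter). Compound 3 is therefore estimated at 9000 nM, between 3000 nM and 30000 nM.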

Compound 3, half-maximal cytotoxic concentration: 15000 nM
Compound 3: middle estimate off by 1.7-fold (0.22 log units), on the low side; the measured number falls inside the stated range.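

In this assay, going from ethyl to propyl on the shared core gives a 1.3-fold higher number from compound 2 to compound 3 (0.10 log units; within the scatter), so the added methyl on the chain does not separate these two compounds. Propyl in place of fluoro gives an at least 6.6-fold lower number from compound 1 to compound 3 (0.82 log units; beyond the scatter), which shows that the propyl compound, like the ethyl compound, stands apart from compound 1. The size of that step stays a bound, as the value of compound 1 is only a limit: the limit of > 100000 nM in this assay, at which 1 of the 3 values shown sits.

From the compounds shown here alone, whether a longer chain, such as butyl, would stay level with propyl remains open. So does the effect of an amine at the chain end.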